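The source may report more compounds than this note shows. Statements on the series, on what has been measured and on what is new or still open speak of the compounds shown alone.

Compounds measured so far:

compound 1, `c1ccc(Cn2c(Nc3ccccc3)nc3ncccc32)cc1`, 52500 nM in a functional assay on MCF7 cells (Homo sapiens) for antiproliferative activity, read by MTT assay, with a stated time of 72 h; on this read-out lower numbers stand for stronger inhibition of growth and higher numbers for weaker inhibition of growth
compound 2, `Clc1ccc(Nc2nc3ncccc3n2Cc2ccccc2)cc1`, 48000 nM
compound 3, `Cn1nc(-c2ccnc(Nc3ccc(O)cc3)n2)c2ccccc21`, 8910 nM

Compound 3 gives the lowest of the three numbers; the step from compound 3 to compound 2 and to compound 1 both lie beyond the scatter. Compound 4, `Cn1nc(-c2ccnc(Nc3ccc(Cl)cc3)n2)c2ccccc21`, differs from compound 3 by chloro in place of hydroxy on an aromatic carbon. Going by the values given here, no measured pair shows this exact exchange. Among the compounds with values here, the only measured step, a 1.1-fold lower number from compound 1 to compound 2 (0.04 log units; within the scatter), concerns a chloro entering in place of hydrogen on a different core and stayed within the scatter, so it bears on compound 4 only loosely. With the hydroxy gone and a chloro entering, compound 4 is expected to sit somewhat higher than compound 3, though the step of a 2.0-fold higher number from compound 3 to compound 4 (0.31 log units; beyond the scatter) is estimated with wide uncertainty. Compound 4 is therefore estimated at 18000 nM, between 5000 nM and 60000 nM.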

Compound 4, concentration for 50% growth inhibition: 7830 nM
Estimate against measurement, compound 4: 2.3-fold (0.36 log units) above, within the range that was stated.
By their numbers in this assay, from the lowest: compounds 4 and 3 (each within the scatter of the next); then compounds 2 and 1 (each within the scatter of the next).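

In this assay, exchanging 4-hydroxyphenyl for 4-chlorophenyl gives a 1.1-fold lower number from compound 3 to compound 4 (0.06 log units; within the scatter). Going by these compounds alone, this is the first measured exchange at this position on this core, and it shows that the read-out holds its level when the hydroxy's hydrogen-bond donor and acceptor leave and a chloro enters. Nothing available explains why the two groups read alike. From the compounds shown here alone, whether an amine, a carboxylic acid or a methoxy group at this position would hold the same level remains open, as does the effect of a longer chain there.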